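From Nitrile to 4-Fluorophenyl: an Expected Gain

The source may report more compounds than this note shows. Statements on the series, on what has been measured and on what is new or still open speak of the compounds shown alone.

Compound 1 `Cc1cc(C#N)nc(NNC(=O)Nc2cc(Cl)nc(Cl)c2)c1` has been tested in a functional assay on CHO cells for antagonist activity at sphingosine 1-phosphate receptor 2 (Homo sapiens), read by fluorescence and calcium flux, with a stated time of 3 min; on this read-out lower numbers stand for stronger inhibition and higher numbers for weaker inhibition. In this assay, going by the values given here, compound 1 gives only a limit rather than a number, > 6600 nM, which is the bound at which one of the two values so far sits (the limit of > 6600 nM in this assay, at which 1 of the 2 values shown sits). A second compound, compound 2 `Cc1cc(NNC(=O)Nc2cc(Cl)nc(Cl)c2)ncc1-c1cnn(C)c1`, carries a different substituent elsewhere on the shared core and is not linked to compound 1 by a single change; in this assay compound 2 gives 2600 nM. Among the compounds with values here, the two values show that a compound of this series can reach a number below the limit, though no step between them is counted.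

Compound 3 `Cc1cc(NNC(=O)Nc2cc(Cl)nc(Cl)c2)nc(-c2ccc(F)cc2)c1` differs from compound 1 by 4-fluorophenyl in place of cyano on an aromatic carbon, next to the ring nitrogen and meta to a methyl group. Within the data shown here, no measured step covers this change, so the expected move is a guess of roughly medium size toward stronger inhibition, and compound 3 is expected at 3000 nM, within 600 nM to 15000 nM. The step from compound 1 to compound 3 is expected as an at least 2.2-fold lower number from compound 1 to compound 3 (0.34 log units; beyond the scatter).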

Compound 3, half-maximal inhibitory concentration: 1300 nM
For compound 3 the middle estimate is 2.3-fold (0.36 log units) above the measured one; the measured number falls inside the stated range.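

Going by these compounds alone, at this place on the shared core, on an aromatic carbon next to the ring nitrogen, the change from cyano to 4-fluorophenyl gives the first counted step: in this assay it is an at least 5.0-fold lower number from compound 1 to compound 3 (0.70 log units; beyond the scatter). The earlier compounds shown here could not show this, as they were not linked by a single change; the step now shows that this place tolerates a six-membered aromatic ring of 7 heavy atoms where the cyano group had 2, and that inhibition strengthens beyond the scatter with that change. The printed size is only a lower bound on the step, because compound 1 gives a limit and not a number: the limit of > 6600 nM in this assay, at which 1 of the 3 values shown sits.

The compounds shown leave open whether the gain comes from the aromatic ring itself or from its fluorine, a question that a plain phenyl group at the same place would address. They also leave open how an amine, a carboxylic acid or a short alkyl chain would read at this place in this assay, so the change cannot yet be placed within any wider trend.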